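Lengthening the Hydrazone Chain: From Compound 2 to Compound 4

The source may hold more compounds than are shown below. What is called first, only, known or untested is meant among the compounds shown, and "the series" means these compounds.

The three measured compounds share one core and differ only in the chain attached through the hydrazone. Compound 1 `CC(C)=NNc1nc(-c2cccc([N+](=O)[O-])c2)cs1` gives 716 nM in an assay on isolated protein for inhibition of Amine oxidase [flavin-containing] B (Homo sapiens), read by fluorescence, with a stated time of 20 min; a higher number here means a weaker inhibitor, a lower number a stronger inhibitor. Compound 2 `CC/C(C)=N\Nc1nc(-c2cccc([N+](=O)[O-])c2)cs1` gives 351 nM, and compound 3 `CCCC/C(C)=N\Nc1nc(-c2cccc([N+](=O)[O-])c2)cs1` gives 118 nM. Compound 2 therefore stands second highest of the three numbers, with compound 1 above it and compound 3 below it; the step of a 2.0-fold lower number from compound 1 to compound 2 (0.31 log units; beyond the scatter) and the step of a 3.0-fold lower number from compound 2 to compound 3 (0.47 log units; beyond the scatter) both point the same way, and together they make the step of a 6.1-fold lower number from compound 1 to compound 3 (0.78 log units; beyond the scatter).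

Compound 4 `CCC/C(CC)=N\Nc1nc(-c2cccc([N+](=O)[O-])c2)cs1` carries a larger group in the same place: a group of 7 heavy atoms (6 carbon, 1 nitrogen; no ring) in place of a group of 5 heavy atoms (4 carbon, 1 nitrogen; no ring), on a nitrogen on an aromatic ring. Each added piece of chain so far lowered the number beyond the scatter, with the smaller addition giving the smaller step, so a further lowering of modest size is expected here. The step of a 2.3-fold lower number from compound 2 to compound 4 (0.37 log units; beyond the scatter) is the estimated outcome. For compound 4 a value of 150 nM is expected, within a range from 60 nM to 400 nM.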

Compound 4, half-maximal inhibitory concentration: 189 nM
Compound 4: middle estimate off by 1.3-fold (0.10 log units), on the low side; the range from low to high includes it.
By their numbers in this assay, from the lowest: compounds 3, 4 and 2 (each within the scatter of the next, the first and the last beyond it); then compound 1.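

Two differently arranged groups of 7 heavy atoms can now be compared at this position, on a nitrogen on an aromatic ring, and with a step of a 1.6-fold higher number from compound 3 to compound 4 (0.20 log units; within the scatter), the two arrangements cannot be told apart. Enlarging the group of 5 heavy atoms to this arrangement gives a step of a 1.9-fold lower number from compound 2 to compound 4 (0.27 log units; within the scatter), so that change has no clear effect, whereas a step of a 3.8-fold lower number from compound 1 to compound 4 (0.58 log units; beyond the scatter) still separates this arrangement clearly from the smaller group. No measurement at hand explains these numbers.

Going by these compounds, whether a longer chain would lower the number further, or whether the numbers have already levelled off at this size, remains open. It is also unknown how a cyclohexyl ring or an amine at this position would compare.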